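Trimming the Phenylpropyl Chain: From Compound 2 to Compound 3

A few compounds are considered here, and "the series" means these few. Any claim that something is new, unique, unknown or untested is made for them only; others in the source may bear on it.

Two compounds sharing one core were measured in an assay for displacement of a labelled ligand from protein arginine N-methyltransferase 1 (Homo sapiens), read by scintillation proximity assay, with stated times of 5 min and 8 min, tested at 10 uM; a lower number here means a weaker effect, a higher number a stronger effect of the compound at the concentration tested. Compound 1 `CC1(C)C(/C=C/C=C2/N(CCCc3ccccc3)c3ccc(Br)cc3C2(C)C)=[N+](CCCc2ccccc2)c2ccc(Br)cc21`, which carries a bromine on each aromatic half and a 3-phenylpropyl chain on each ring nitrogen, gives 101%. Compound 2 `CN1/C(=C/C=C/C2=[N+](CCCc3ccccc3)c3ccccc3C2(C)C)C(C)(C)c2ccccc21`, with one 3-phenylpropyl chain and a methyl on the other ring nitrogen, gives 35%. Compound 2 thus stands lowest of the two numbers, and the gap to compound 1 is well beyond the scatter of this assay.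

Compound 3 `CC[N+]1=C(/C=C/C=C2/N(C)c3ccccc3C2(C)C)C(C)(C)c2ccccc21` has not yet been measured. It differs from compound 2 in one place: hydrogen in place of benzyl on a saturated chain carbon, two bonds along the chain from a double-bonded nitrogen in a ring. Cut one bond further out, the same change reads phenethyl to methyl, or 3-phenylpropyl to ethyl.

Among the compounds with values here, no step between two measured compounds isolates this change, so its size can only be guessed. Since compound 2 gives 35% after already losing one 3-phenylpropyl chain relative to compound 1, the account expects a further fall, with the step of a number 20 percentage points lower from compound 2 to compound 3 (beyond the scatter) likely beyond the scatter. Compound 3 is therefore expected to give about 15%, within a range from 0% to 40%.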

Compound 3, a percentage reported as inhibition, at one concentration (the size of the read-out at that concentration, not a potency): "not active" (no number reported)
Compound 3 has no reported number here; there is nothing to compare the estimate with.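

In this assay, within the data shown here, compound 3 is reported only as "not active", with no number, so no step from compound 2 to compound 3 can be read. Nothing given here bears on this result. The compounds shown leave open how large the effect of exchanging 3-phenylpropyl for ethyl alone is on this read-out.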